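Swapping One Halogen on a Weak Inhibitor

The source may report more compounds than this note shows. Statements on the series, on what has been measured and on what is new or still open speak of the compounds shown alone.

Compound 1, with the structure `O=C(Cn1cc(-c2ccc(F)cc2)nn1)Nc1nc2ccccc2s1`, was tested in a functional assay on BMDM cells (Mus musculus, strain C57BL/6) for inhibition, with a stated time of 2 days; a lower number here means a stronger inhibitor, a higher number a weaker inhibitor. In that assay compound 1 gave > 30000 nM, which is a limit of the assay rather than a measured number. A second compound, compound 2 `COc1cccc(-c2cn(-c3ccc(C(F)(F)F)cc3)nc2C(=O)NC2CCCCC2)c1`, was also tested in this assay. Compound 2 gave > 30000 nM, again a limit and not a number. Among the compounds with values here, compound 1 therefore stands at the edge of what this assay can report, and the only other value shown sits at the same edge: the limit of > 30000 nM in this assay, at which 2 of the 2 values shown sit. Within the data shown here, no two measured compounds differ in a single place, so no measured step is available.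

Compound 3 `O=C(Cn1cc(-c2ccccc2Cl)nn1)Nc1nc2ccccc2s1` is the next compound to be measured. It differs from compound 1 in one place: 2-chlorophenyl in place of 4-fluorophenyl on an aromatic carbon. Because compound 1 sits at the limit of > 30000 nM in this assay, at which 2 of the 2 values shown sit, any estimate for compound 3 rests on this structural change alone. The step is expected to be a number no higher from compound 1 to compound 3 (the limit leaves the size open), nothing beyond the usual scatter. Compound 3 is accordingly expected to give about 30000 nM in this assay, within an estimated range from 10000 nM to 100000 nM, most likely again reported only as a limit.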

Compound 3, half-maximal inhibitory concentration: > 30000 nM
Compound 3: no number, only a limit (the forecaster's own chance of this, stated with the estimate: 80%); the middle value lies on the limit itself.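

Compound 3 gives > 30000 nM in this assay, which is a limit of the assay and not a number. No step from compound 1 to compound 3 can be read, because both compounds stop at the same edge: the limit of > 30000 nM in this assay, at which 3 of the 3 values shown sit.

The compounds shown leave open how 2-chlorophenyl and 4-fluorophenyl actually compare, and what structure would give a true number in this assay.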